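This account rests on a few compounds, and the source may have more. Where it says the series, first, only, none or still open, it means among the compounds named here.

Measured compounds in an ADME assay on HeLa cells (Homo sapiens) for cytotoxicity, with a stated time of 72 h; on this read-out lower numbers stand for higher toxicity in this test and higher numbers for lower toxicity in this test:
compound 1 `COC(=O)[C@@H]1OC2(CCN(c3nc(=O)c4cc(C(F)(F)F)cc([N+](=O)[O-])c4s3)CC2)O[C@H]1c1ccccc1` — > 50000 nM
compound 2 `COC(=O)C1CN(c2nc(=O)c3cc(C(F)(F)F)cc([N+](=O)[O-])c3s2)CCC12OC[C@H](C)O2` — 36000 nM
compound 3 `O=c1nc(N2CCC(F)(F)CC2)sc2c([N+](=O)[O-])cc(C(F)(F)F)cc12` — "not determined" (no result reported)

Compound 1 gives only a limit in this assay, > 50000 nM, which is a limit of the measurement and not a number. Compound 2 gives 36000 nM in this assay, a number that places it among the weakly toxic compounds of the set. For compound 3 no number has been reported in this assay, so it cannot be placed on the scale; of the values shown, one sits at the limit of > 50000 nM in this assay, at which 1 of the 3 values shown sits, and the other is the number of compound 2.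

Compound 4 `Cc1ccc(CNc2nc(=O)c3cc(C(F)(F)F)cc([N+](=O)[O-])c3s2)n1C` is the next compound to be measured in this assay. It differs from compound 3 by ((1,5-dimethyl-1H-pyrrol-2-yl)methyl)amino in place of 4,4-difluoropiperidin-1-yl on an aromatic carbon.

Going by the values given here, no step between two measured compounds exists in this assay, and compound 3 itself carries no number, so the change from compound 3 to compound 4 has no measured reference. The two compounds with numbers or limits on the shared core both sit at the weakly toxic end of this assay, and no step beyond the scatter in either direction is expected for compound 4 relative to them. Compound 4 is expected to give about 30000 nM in this assay, with a range from 8000 nM to 50000 nM.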

Compound 4, half-maximal cytotoxic concentration: 48000 nM
Beside the measured number, compound 4's estimate is 1.6-fold (0.20 log units) below it, within the range that was stated.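

Going by these compounds alone, compound 3 carries no number in this assay, and no step to compound 4, at 48000 nM, can be read. The compounds shown leave open what replacing 4,4-difluoropiperidin-1-yl with ((1,5-dimethyl-1H-pyrrol-2-yl)methyl)amino on the shared core does in this assay.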